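Methyl additions on the amine side chain: ileum inhibition notes

The source may hold more compounds than are shown below. What is called first, only, known or untested is meant among the compounds shown, and "the series" means these compounds.

Compound 1 `Oc1nc(NCc2ccccc2)nc2ccc(Cl)cc12` and compound 2 `C[C@H](Nc1nc(O)c2cc(Cl)ccc2n1)c1ccccc1` share one core and differ by methyl in place of hydrogen on a saturated chain carbon bound to an aromatic carbon and a nitrogen on an aromatic ring. In a functional assay (ileum) for inhibition, with Cavia porcellus as the target (on this read-out higher numbers stand for weaker inhibition and lower numbers for stronger inhibition), compound 1 gives 13300 nM and compound 2 gives 13200 nM; the step is a 1.0-fold lower number from compound 1 to compound 2 (0.00 log units; within the scatter). Compound 3 `CCC(C)Nc1nc(O)c2cc(I)ccc2n1` carries a different core; the difference between the two cores is not broken down here. In this assay compound 3 gives 23600 nM, within the scatter of compound 1 and compound 2. Compound 4 `CC(C)C(C)Nc1nc(O)c2cc(I)ccc2n1` is not yet measured and differs from compound 3 by methyl in place of hydrogen on a saturated chain carbon bound to two saturated chain carbons. This is the same kind of change as from compound 1 to compound 2, but not the same: there the place was a saturated chain carbon bound to an aromatic carbon and a nitrogen on an aromatic ring, here it is a saturated chain carbon bound to two saturated chain carbons. Resting on the one measured step of this kind, which is a 1.0-fold lower number from compound 1 to compound 2 (0.00 log units; within the scatter), the step expected in this assay is a 1.1-fold higher number from compound 3 to compound 4 (0.03 log units; within the scatter). Compound 4 is estimated at 25000 nM, with an expected range from 10000 nM to 60000 nM.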

Compound 4, half-maximal inhibitory concentration: 30400 nM
The estimate for compound 4 lay 1.2-fold (0.08 log units) below the measured number; measured number inside the range.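

In this assay the methyl addition gives a 1.3-fold higher number from compound 3 to compound 4 (0.11 log units; within the scatter), and set beside the earlier step it shows no difference between the two cores: the same change on two cores in this assay, a 1.0-fold lower number (0.00 log units; within the scatter) from compound 1 to compound 2 and a 1.3-fold higher number (0.11 log units; within the scatter) from compound 3 to compound 4, 1.3-fold (0.11 log units) apart, within the scatter of two such steps.
Within these two pairs, methyl in place of hydrogen therefore carries across the cores with no step beyond the scatter. Within the data shown here, this does not show that the change is without effect in general: only two pairs support it, the place differs between them, and neither step gives a direction.

Still open, from the compounds shown here alone, is whether a longer chain, such as n-hexyl, on the amine side chain would give a step beyond the scatter. The same question stands for a cyclohexyl ring or a carboxylic acid there.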